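Working notes: sulfonate-to-anilino change on the shared core

The source may report more compounds than this note shows. Statements on the series, on what has been measured and on what is new or still open speak of the compounds shown alone.

Measured so far:
compound 1 `C=C[C@@](C)(/C=C/c1ccc(OS(=O)(=O)C(F)(F)F)cc1)CCC=C(C)C` — in a functional assay on NALM-6 cells (Homo sapiens) for cytotoxicity, with a stated time of 72 h (a higher number here means that more compound is needed for the effect, a lower number that less compound is needed), compound 1 gives the limit > 43400 nM.
compound 2 `C=C[C@@](C)(/C=C/c1ccc(OS(=O)(=O)c2ccc(C)cc2)cc1)CCC=C(C)C` — in this assay compound 2 gives the limit > 43400 nM.

Compound 1 stands only at a limit, not at a number. The step that the two limits leave unreadable from compound 1 to compound 2 cannot be read because both values sit at the limit of > 43400 nM in this assay, at which 2 of the 2 values shown sit. So the single measured step, from compound 1 to compound 2, gives no readable size and no direction.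

Compound 3 `C=C[C@@](C)(/C=C/c1ccc(Nc2cc(F)cc(F)c2)cc1)CCC=C(C)C` is not yet measured. Against compound 1 it shows ((3,5-difluorophenyl)amino in place of ((trifluoromethyl)sulfonyl)oxy on an aromatic carbon). Among the compounds with values here, no measured step touches an aromatic amine at this position, so the expectation rests on nothing firmer than the two limits. With both measured compounds at the limit, compound 3 is expected to be no more active than them, and it is estimated at 30000 nM, within 5000 nM to 100000 nM. The implied step an at least 1.4-fold lower number from compound 1 to compound 3 (0.16 log units; that floor lies within the scatter) is expected to lie within the scatter, if readable at all.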

Compound 3, half-maximal effective concentration: > 43400 nM
Compound 3 gave a limit, no number; the forecaster's own chance of this, stated with the estimate: 60%; at least 1.4-fold (0.16 log units) between middle value and limit.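

Compound 3 gives only a limit, not a number, and the step from compound 1 to compound 3 cannot be read: the limit of > 43400 nM in this assay, at which 3 of the 3 values shown sit.

The compounds shown leave open whether any group on this aromatic carbon of the shared core gives a readable value in this assay, and how compound 1, compound 2 and compound 3 rank.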